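A few compounds are considered here, and "the series" means these few. Any claim that something is new, unique, unknown or untested is made for them only; others in the source may bear on it.

In a functional assay on KB cells (Homo sapiens) for cytotoxicity, read by spectrophotometry and crystal violet staining (on this read-out higher numbers stand for weaker inhibition and lower numbers for stronger inhibition), the measured compounds stand as follows:

Compound 1 `COc1c(C#N)c2cc(Cl)c(Cl)cc2n1[C@H]1C[C@H](O)[C@@H](CO)O1` gives > 100000 nM as a limit of the assay
Compound 2 `COc1c(C=O)c2cc(Cl)c(Cl)cc2n1[C@H]1C[C@H](O)[C@@H](CO)O1` gives 20000 nM
Compound 3 `CC(=O)c1c(Cl)n([C@H]2C[C@H](O)[C@@H](CO)O2)c2cc(Cl)c(Cl)cc12` gives 400000 nM

Compound 3 gives 400000 nM and so carries the highest of the actual numbers, with compound 2 nearest at 20000 nM on the same scale. Compound 4 `OC[C@H]1O[C@@H](n2c(Cl)c(-c3ccsc3)c3cc(Cl)c(Cl)cc32)C[C@@H]1O` differs from compound 3 in one place, with thiophen-3-yl in place of acetyl on an aromatic carbon.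

Within the data shown here, the only measured step (an at least 5.0-fold lower number from compound 1 to compound 2 (0.69 log units; beyond the scatter)) puts formyl in place of cyano on an aromatic carbon. Going by these compounds, its size stays open at one end, resting on the limit of > 100000 nM in this assay, at which 1 of the 3 values shown sits, and nothing more. That step involves neither acetyl nor thiophen-3-yl, so it bears only loosely, as a sign that one change of group can move the number beyond the scatter. A modest move toward a lower number is therefore expected, given that compound 3 gives 400000 nM on this scale. The expected step is a rough one (a 6.7-fold lower number from compound 3 to compound 4 (0.82 log units; beyond the scatter)). In this assay compound 4 is estimated at 60000 nM with a range from 10000 nM to 400000 nM expected.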

Compound 4, half-maximal inhibitory concentration: 50000 nM
Compound 4: the middle estimate sits 1.2-fold (0.08 log units) above what was measured, and the stated range covers the measured number.
By their numbers in this assay, from the lowest: compound 2; then compound 4; then compound 3.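

In this assay, placing a ring on this aromatic carbon, next to the ring atom that bears a chloro group, gives an 8.0-fold lower number from compound 3 to compound 4 (0.90 log units; beyond the scatter). This is the first step shown with an actual number at both ends, so its size is fixed, and it is a modest one. The hydrogen-bond donor and acceptor counts of the leaving and entering groups are the same, so the change lies in acetyl giving way to a five-membered aromatic ring, though the data shown offer no measured reason for the step.

The compounds shown leave open whether the lower number follows from the thiophen-3-yl group itself or simply from the loss of acetyl. A phenyl ring, a thiophen-2-yl group or an amine on this same carbon would help to separate the two.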